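A Second Fluorine on the Benzyl Group and Cell Toxicity

The source may hold more compounds than are shown below. What is called first, only, known or untested is meant among the compounds shown, and "the series" means these compounds.

Measured so far in an ADME assay on MT4 cells (Homo sapiens) for cytotoxicity, read by MTT assay; on this read-out lower numbers stand for higher toxicity in this test and higher numbers for lower toxicity in this test:
compound 1, `COc1cccc2c1c(C(=O)/C=C(\O)C(=O)O)cn2Cc1ccccc1F`, gives 70500 nM;
compound 2, `CCOC(=O)/C(O)=C/C(=O)c1cn(Cc2cccc(F)c2)c2cccc(OC)c12`, gives 63200 nM;
compound 3, `COc1cccc2c1c(C(=O)/C=C(\O)C(=O)O)cn2Cc1ccc(F)cc1F`, gives 20800 nM.

Compounds 1 and 2 differ in more than one place, and the difference between the two cores is not broken down here; their values in this assay lie within the scatter of each other. Compound 3 arises from compound 1 by fluoro in place of hydrogen on an aromatic carbon. This change gave a 3.4-fold lower number from compound 1 to compound 3 (0.53 log units; beyond the scatter).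

Compound 4, `CCOC(=O)/C(O)=C/C(=O)c1cn(Cc2cccc(F)c2F)c2cccc(OC)c12`, has not yet been measured in this assay. It arises from compound 2 by fluoro in place of hydrogen on an aromatic carbon. This is the same kind of change as before, but its surroundings differ: in compound 3 the new fluoro sits meta to a fluoro group and para to a large group, whereas in compound 4 it sits ortho to a fluoro group and ortho to a large group. Resting on the single measured example a 3.4-fold lower number from compound 1 to compound 3 (0.53 log units; beyond the scatter), the expected step is a 2.3-fold lower number from compound 2 to compound 4 (0.35 log units; beyond the scatter), held a little smaller since the place is not the same. Compound 4 is thus expected to give about 28000 nM in this assay, with a likely range from 12000 nM to 65000 nM.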

Compound 4, half-maximal cytotoxic concentration: 21100 nM
Compound 4: middle estimate off by 1.3-fold (0.12 log units), on the high side, and the stated range covers the measured number.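

Adding a second fluoro to the benzyl group again made the compound more toxic to the cells in this assay, with a 3.0-fold lower number from compound 2 to compound 4 (0.48 log units; beyond the scatter). Set beside the earlier example, the change carried over from one core to the other with much the same size: the same change on two cores in this assay, a 3.4-fold lower number (0.53 log units; beyond the scatter) from compound 1 to compound 3 and a 3.0-fold lower number (0.48 log units; beyond the scatter) from compound 2 to compound 4, 1.1-fold (0.05 log units) apart, within the scatter of two such steps. Among the compounds shown here, this is encouraging for carrying the change across this series, but it rests on only two pairs, and it does not show that the step would keep this size on other cores or at other places on the ring, nor does it explain why the number falls.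

The compounds shown leave open whether a chloro or methyl group in place of the added fluoro would lower the number in the same way. They also leave open how an amide in place of the ethyl ester or the carboxylic acid would behave in this assay.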